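Lengthening a Side Chain in a Rat Whole-Animal Series

The compounds below may be only part of what the source reports. "The series", "measured", "known", "first", "only" and "open" are said of these compounds alone.

Three members of one series have been measured in a functional assay on the whole organism for inhibition, with Rattus norvegicus as the target; on this read-out lower numbers stand for an effect already at smaller amounts and higher numbers for an effect only at larger amounts of compound. Compound 1 `Cc1ccc(CC(C)(Oc2ccc(C(C)C)cc2)C(=O)O)cc1` reaches only a limit of the assay in this assay, namely < 1 mg/kg, and that limit stands for a reading of the dose rather than a number. Compound 2 `CCc1ccc(CC(C)(Oc2ccc(C(C)C)cc2)C(=O)O)cc1` gives 0.1 mg/kg in this assay. The change that turns compound 1 into compound 2 is methyl in place of hydrogen on a saturated chain carbon bound to an aromatic carbon, and its size cannot be read, because the limit of < 1 mg/kg in this assay, at which 1 of the 3 values shown sits, hides where compound 1 truly lies; it appears as a step that the limit leaves unreadable from compound 1 to compound 2. Compound 3 `CCc1ccc(CC(C)(Oc2ccc(Cc3ccccc3)cc2)C(=O)O)cc1` gives 1 mg/kg in this assay, and the step is a 10-fold higher number from compound 2 to compound 3 (1.00 log units; beyond the scatter), which rests on (benzyl in place of isopropyl on an aromatic carbon). How the core of compound 1 and the core of compound 3 differ is not broken down here.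

Compound 4 `CCCc1ccc(CC(C)(Oc2ccc(Cc3ccccc3)cc2)C(=O)O)cc1` is not yet measured. It arises from compound 3 by methyl in place of hydrogen on a saturated chain carbon, two bonds along the chain from an aromatic carbon. Within the data shown here, this is the same kind of change as the one from compound 1 to compound 2, but not the same: there the methyl entered on a saturated chain carbon bound to an aromatic carbon, whereas here it enters on a saturated chain carbon, two bonds along the chain from an aromatic carbon. Since the earlier step is unreadable, compound 4 is expected to sit close to compound 3, as no change at the digits printed from compound 3 to compound 4 (within the scatter), giving an estimated 1 mg/kg in this assay, most likely between 0.3 mg/kg and 3 mg/kg.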

Compound 4, dose for half-maximal effect: 1 mg/kg
The estimate for compound 4 equals the measured number at the digits printed; measured number inside the range.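

On the core of compound 3, lengthening ethyl to propyl gives no change at the digits printed from compound 3 to compound 4 (within the scatter) in this assay, so on this core the added methyl leaves no readable mark on the dose needed. The closest comparison is the step from compound 1 to compound 2, where the methyl enters on a saturated chain carbon bound to an aromatic carbon, on a core carrying isopropyl rather than benzyl, and that step cannot be read, because compound 1 is held at a limit of the assay and not at a number: the limit of < 1 mg/kg in this assay, at which 1 of the 4 values shown sits. The result therefore shows that the change is without effect on one core at one place in the chain, but it does not show that the change would behave in the same way on the core of compound 1, since no readable step exists there to set beside it.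

The compounds shown stop at propyl, so it stays open whether a longer chain such as butyl or pentyl in the same place would also leave the number in this assay unmoved. From the compounds shown here alone, it also stays open how a chain ending in an amine or a hydroxyl group would compare, and how propyl would behave on the core that carries isopropyl.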